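Acylhydrazone series, epithelial cell inhibition: step to compound 3

A few compounds are considered here, and "the series" means these few. Any claim that something is new, unique, unknown or untested is made for them only; others in the source may bear on it.

Measured so far:
compound 1 `CC(C)(C)c1ccc2c(c1)OC(C(=O)N/N=C/c1ccc[nH]1)CO2` — 15000 nM
compound 2 `Cc1ccc(/C=N/NC(=O)COc2ccc(Cl)cc2Cl)[nH]1` — 16900 nM

In an ADME assay on cells (Epithelial cell, Homo sapiens) for inhibition (on this read-out lower numbers stand for an effect already at smaller amounts and higher numbers for an effect only at larger amounts of compound), compound 1 gives 15000 nM and compound 2 gives 16900 nM. Compound 2 carries the higher of the two numbers, but the gap to compound 1 lies within the scatter, so the two compounds are treated as equal on this read-out. Both sit at the weak end.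

Compound 3 `O=C(COc1ccc(Cl)cc1Cl)N/N=C/c1ccccc1O` is not yet measured in this assay. It differs from compound 2 in one place: 2-hydroxyphenyl in place of 5-methyl-1H-pyrrol-2-yl on a carbon with a double bond to nitrogen. Among the measured compounds shown here, no measured pair shows such a change, so its size is unknown here. Given that compound 2 gives 16900 nM and compound 1 gives 15000 nM with no movement between them, the expected step of a 1.1-fold lower number from compound 2 to compound 3 (0.05 log units; within the scatter) is none beyond the scatter. Compound 3 is estimated at 15000 nM, with a range of 5000 nM to 45000 nM.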

Compound 3, half-maximal effective concentration: 56300 nM
Estimate against measurement, compound 3: 3.8-fold (0.57 log units) below; measured number above the stated range.
By their numbers in this assay, from the lowest: compounds 1 and 2 (each within the scatter of the next); then compound 3.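

In this assay, among the compounds shown here, the group on a carbon with a double bond to nitrogen can move the read-out: 2-hydroxyphenyl in place of 5-methyl-1H-pyrrol-2-yl gives a 3.3-fold higher number from compound 2 to compound 3 (0.52 log units; beyond the scatter) and is the only step that can be read. This single change replaces a five-membered aromatic ring with one hetero atom by a six-membered aromatic ring of carbon only and also adds a hydrogen-bond acceptor, so these differences cannot be told apart here. No measurement available bears on the reason for the step.

Whether the ring itself or its hydroxy group accounts for the step remains open. Unsubstituted phenyl at this place, or an amine in place of the hydroxy group on that ring, would bear on that question.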